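This account rests on a few compounds, and the source may have more. Where it says the series, first, only, none or still open, it means among the compounds named here.

Measured compounds in a functional assay on cells (Peritoneal macrophage, Mus musculus) for cytotoxicity, with a stated time of 24 h; a lower number here means that less compound is tolerated, a higher number that more compound is tolerated:
compound 1, `CCC(=O)Nc1ccc(S(=O)(=O)N(CC(N)=O)c2ccc(N(CC(N)=O)S(=O)(=O)c3ccc(OC)cc3)c3ccccc23)cc1`, gives > 50000 nM
compound 2, `CCCC(=O)Nc1ccc(S(=O)(=O)N(CC(N)=O)c2ccc(N(CC(N)=O)S(=O)(=O)c3ccc(OC)cc3)c3ccccc23)cc1`, gives > 100000 nM
compound 3, `CCCCC(=O)Nc1ccc(S(=O)(=O)N(CC(N)=O)c2ccc(N(CC(N)=O)S(=O)(=O)c3ccc(OC)cc3)c3ccccc23)cc1`, gives > 100000 nM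

All three values are limits of this assay, not numbers. Compound 1 stands at the limit of > 50000 nM in this assay, at which 1 of the 3 values shown sits. Compound 2 stands at the limit of > 100000 nM in this assay, at which 2 of the 3 values shown sit. Compound 3 also stands at the limit of > 100000 nM in this assay, at which 2 of the 3 values shown sit, so only a limit is known for it, and the two other values shown are limits as well. The steps among these compounds, a step that the two limits leave unreadable from compound 1 to compound 2, a step that the two limits leave unreadable from compound 1 to compound 3 and a step that the two limits leave unreadable from compound 2 to compound 3, therefore cannot be read in size or direction; the data show only that the growing chain on the amide carbonyl did not bring tolerance down to a measurable value.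

Compound 4, `COc1ccc(S(=O)(=O)N(CC(N)=O)c2ccc(N(CC(N)=O)S(=O)(=O)c3ccc(NC(=O)CN4CCC(C)CC4)cc3)c3ccccc23)cc1`, differs from compound 3 by 4-methylpiperidin-1-yl in place of propyl on a saturated chain carbon bound to a carbonyl carbon. No measured step bears on this kind of change, and the three steps that are shown are themselves unreadable. Within the data shown here, the only guide is that compounds 1, 2 and 3 all sit at limits, so compound 4 is expected to remain at or near the limit as well, with a number no higher from compound 3 to compound 4 (the limit leaves the size open) expected to be no step beyond the scatter. For compound 4 in this assay the estimate is 100000 nM, within 30000 nM to 300000 nM.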

Compound 4, half-maximal cytotoxic concentration: > 50000 nM
Compound 4: only a limit was reported (the forecaster's own chance of this, stated with the estimate: 80%); the middle value does not contradict the limit.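

In this assay compound 4 gives > 50000 nM, which is a limit and not a number. Compound 1, compound 2 and compound 3 also stand at limits, so none of the steps to compound 4 can be read in size or direction. The compounds shown leave open whether 4-methylpiperidin-1-yl in place of propyl changes tolerance at all.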